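The compounds below may be only part of what the source reports. "The series", "measured", "known", "first", "only" and "open" are said of these compounds alone.

Compound 1 `O=C(Nc1ccccc1)c1ccc(C(=O)O)nc1` carries an amide that joins a phenyl ring to the shared core. In an assay on isolated protein (Gallus gallus) for inhibition of transmembrane prolyl 4-hydroxylase (Homo sapiens) (a higher number here means a weaker inhibitor, a lower number a stronger inhibitor), compound 1 gives 26500 nM. Compound 2 `O=C(Nc1ccccc1Cl)c1ccc(C(=O)O)nc1` differs from it by chloro in place of hydrogen on an aromatic carbon, and in this assay compound 2 gives 16300 nM. The step between them is a 1.6-fold lower number from compound 1 to compound 2 (0.21 log units; within the scatter).

Compound 3 `O=C(Nc1ccc(C(=O)O)nc1)c1ccccc1` is built from the same atoms as compound 1, but joined differently; the difference between the two cores is not broken down here. In this assay compound 3 gives 25600 nM, which sits close to the number for compound 1 and not far from the number for compound 2.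

Compound 4 `O=C(Nc1ccc(C(=O)O)nc1)c1ccc(Cl)cc1` has not yet been measured. It differs from compound 3 by chloro in place of hydrogen on an aromatic carbon. Among the compounds with values here, this is the same kind of change as the one from compound 1 to compound 2, though not the same: in compound 2 the chloro sits ortho to a large group, in compound 4 it sits para to a large group. Because the change from compound 1 to compound 2 produced only a 1.6-fold lower number from compound 1 to compound 2 (0.21 log units; within the scatter), the expectation for compound 4 is a step of comparable size, a 1.4-fold lower number from compound 3 to compound 4 (0.15 log units; within the scatter), starting from the number for compound 3. On that basis compound 4 is estimated at 18000 nM in this assay, with a range from 8000 nM to 40000 nM that allows for the change of place around the chloro.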

Compound 4, half-maximal inhibitory concentration: 22500 nM
Compound 4: middle estimate off by 1.3-fold (0.10 log units), on the low side; the range from low to high includes it.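

In this assay, chloro in place of hydrogen on an aromatic carbon gives a 1.1-fold lower number from compound 3 to compound 4 (0.06 log units; within the scatter), and set beside the earlier step on the other core, the change shows no difference that stands clear of the scatter: the same change on two cores in this assay, a 1.6-fold lower number (0.21 log units; within the scatter) from compound 1 to compound 2 and a 1.1-fold lower number (0.06 log units; within the scatter) from compound 3 to compound 4, 1.4-fold (0.16 log units) apart, within the scatter of two such steps. What this shows is modest: on both cores the chloro leaves the number within the scatter of its parent, and the two steps agree in that limited sense. It does not show that an effect of this change carries from one core to the other, as neither step is large enough to be told from the scatter, and the comparison also mixes two differences, with the chloro para to a large group in compound 4 and at a different place in compound 2, so the core and the place cannot be separated.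

The compounds shown leave open whether chloro at one and the same place on both cores would give matching steps. They also leave open whether another group on the phenyl ring, such as a methoxy group, an amine or a carboxylic acid, would move the number beyond the scatter on either core, and whether any such step would carry across.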